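The compounds below may be only part of what the source reports. "The series", "measured", "known", "first", "only" and "open" are said of these compounds alone.

Compound 1, `CC(=O)N[C@@H]1CCCc2c1cncc2N1C(=O)c2ccc(Cl)cc2[C@H]1C1CC1`, is the weaker of the two compounds measured in an ADME assay on cells for inhibition of cytochrome P450 11B1, mitochondrial (Homo sapiens), read by HTRF; a lower number here means a stronger inhibitor, a higher number a weaker inhibitor: compound 1 gives 22800 nM, while compound 2, `CC[C@@H]1c2cc(Cl)ccc2C(=O)N1c1cncc2c1CCC[C@H]2NC(C)=O`, gives 334 nM, a step of a 68-fold lower number from compound 1 to compound 2 (1.83 log units; beyond the scatter) that comes from an ethyl in place of cyclopropyl on a saturated ring carbon. Compound 3, `CC(=O)N[C@@H]1CCCc2c1cncc2N1C(=O)c2ccc(Cl)cc2[C@@H]1C1CC1`, differs from compound 1 in another way: the two compounds have the same atoms and bonds and differ only in configuration as drawn: 1 of 2 stereo elements differ; a stereocentre at a saturated ring carbon is drawn R in compound 1 and S in compound 3. Within the data shown here, no measured step concerns such a change in configuration, so the one step known gives no guidance here, and the direction is open. Compound 3 is therefore estimated at 9000 nM, between 1000 nM and 60000 nM, a step of a 2.5-fold lower number from compound 1 to compound 3 (0.40 log units; beyond the scatter) taken as a guess rather than an inference.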

Compound 3, half-maximal inhibitory concentration: > 30000 nM
Compound 3 ended at the assay's limit; the forecaster's own chance of this, stated with the estimate: 10%; at least 3.3-fold (0.52 log units) between middle value and limit.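

In this assay compound 3 gives > 30000 nM, which is a limit of the assay and not a number. Turning the stereocentre at a saturated ring carbon from R to S, with no atom added or lost, gives an at least 1.3-fold higher number from compound 1 to compound 3 (0.11 log units; that floor lies within the scatter), so the direction is not settled by the printed floor alone. The true size of this step stays unknown because the reading stops at a ceiling: the limit of > 30000 nM in this assay, at which 1 of the 3 values shown sits.

Open, on these data alone, is what the same change in configuration does when ethyl replaces cyclopropyl on that carbon. Also open, as far as these compounds go, is how a longer chain or an amine there would compare.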